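This account rests on a few compounds, and the source may have more. Where it says the series, first, only, none or still open, it means among the compounds named here.

Compound 1 `CCCCCCCCCCCCCCCCc1nc(OC2CCC2)nc(N2CCC2)c1O`: 110%
Compound 2 `CCCCCCCCCCCCCCCCc1nc(OC2CCC2)nc(OC2CCC2)c1O`: 102%

Both compounds were tested in a functional assay on cells (Lymphocyte, Homo sapiens), read by a luciferase reporter and ATP content, with a stated time of 48 h, tested at 5 uM; on this read-out lower numbers stand for a stronger effect and higher numbers for a weaker effect at the one concentration tested. Compound 1 gives 110%, and compound 2 gives 102%; the step of a number 8 percentage points lower from compound 1 to compound 2 (within the scatter) lies within the scatter, so compound 1 is not set apart from compound 2 on the numbers shown. Compound 3 `CCCCCCCCCCCCCCCCc1nc(N2CCC2)nc(N2CCC2)c1O` has not yet been measured. It differs from compound 1 in one place: azetidin-1-yl in place of cyclobutyloxy on an aromatic carbon. For the measured compounds named here, the only measured step that bears on this change is the exchange between compound 1 and compound 2, the same pair of groups swapped in the opposite sense at a different aromatic carbon of the shared core, and that step, a number 8 percentage points lower from compound 1 to compound 2 (within the scatter), fell within the scatter. On this basis no step beyond the scatter is expected from compound 1 to compound 3, which is a number 5 percentage points lower from compound 1 to compound 3 (within the scatter). Compound 3 is therefore estimated at 105%, with a likely range from 90% to 120%.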

Compound 3, a percentage reported as activity, at one concentration (the size of the read-out at that concentration, not a potency): 61%
Compound 3: the middle estimate sits 44 percentage points above what was measured, outside the stated range (below it).
By their numbers in this assay, from the lowest: compound 3; then compounds 2 and 1 (each within the scatter of the next).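

In this assay, for the compounds shown here, azetidin-1-yl in place of cyclobutyloxy on the aromatic carbon between two ring nitrogen atoms, para to a hydroxy group, gives a number 49 percentage points lower from compound 1 to compound 3 (beyond the scatter), the only step in this set that lies beyond the scatter. The same two groups exchanged in the opposite sense at the other aromatic carbon of the shared core gave a number 8 percentage points lower from compound 1 to compound 2 (within the scatter), so the exchange does not read alike at the two places. Nothing available explains the step at this position.

The compounds shown leave open whether another amine at this position, such as pyrrolidin-1-yl or dimethylamino, would read like azetidin-1-yl. They also leave open whether the step would persist with a shorter chain in place of the long alkyl chain.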